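A few compounds are considered here, and "the series" means these few. Any claim that something is new, unique, unknown or untested is made for them only; others in the source may bear on it.

Compound 1 `N#C/C(=C\c1ccco1)C(=O)NCc1ccc(Cl)c(Cl)c1` carries furan-2-yl on a double-bonded chain carbon bound to a double-bonded chain carbon. In a functional assay on SW480 cells (Homo sapiens) for inhibition, read by MTT assay, with a stated time of 72 h (on this read-out higher numbers stand for weaker inhibition of growth and lower numbers for stronger inhibition of growth), compound 1 gives > 50000 nM, which is a limit of the assay and not a number. The two members with numbers are compound 2 `COc1ccc(CNC(=O)/C(C#N)=C/c2ccc(Br)o2)cc1` and compound 3 `COc1ccc(CNC(=O)/C(C#N)=C/c2ccc(Cl)cc2)cc1`. In this assay compound 2 gives 14000 nM. In this assay compound 3 gives 10000 nM. Compound 1 thus stands only at the limit (the limit of > 50000 nM in this assay, at which 1 of the 3 values shown sits), without a number of its own.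

Compound 4 `N#C/C(=C\c1ccc(Cl)cc1)C(=O)NCc1ccc(Cl)c(Cl)c1` differs from compound 1 by 4-chlorophenyl in place of furan-2-yl on a double-bonded chain carbon bound to a double-bonded chain carbon. For the measured compounds named here, the one measured step that bears on this exchange is a 1.4-fold lower number from compound 2 to compound 3 (0.15 log units; within the scatter), where 4-chlorophenyl replaced 5-bromofuran-2-yl at the same place and the number stayed within the scatter. On that basis no step beyond the scatter is expected in this assay from compound 1 to compound 4, and because compound 1 sits at > 50000 nM the result for compound 4 may again be a limit rather than a number. Compound 4 is estimated at 45000 nM, with a range from 15000 nM to 100000 nM. The expected step is an at least 1.1-fold lower number from compound 1 to compound 4 (0.04 log units; that floor lies within the scatter).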

Compound 4, concentration for 50% growth inhibition: 30000 nM
Compound 4: the middle estimate sits 1.5-fold (0.18 log units) above what was measured; the range from low to high includes it.
By their numbers in this assay, from the lowest: compounds 3 and 2 (each within the scatter of the next); then compound 4. At a limit, above all of these: compound 1.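

At this place, on a double-bonded chain carbon bound to a double-bonded chain carbon, 4-chlorophenyl in place of furan-2-yl gives in this assay an at least 1.6-fold lower number from compound 1 to compound 4 (0.22 log units; that floor lies within the scatter). The change thus turns a limit into a number on the core of compound 1, a result the earlier pair, with numbers on both sides, could not show. Only a floor is known for this step, and compound 1 stands at a limit: the limit of > 50000 nM in this assay, at which 1 of the 4 values shown sits.

On these data alone, whether a true number for compound 1 would place the step beyond the scatter remains open. Also open, as far as these compounds go, is how a 4-aminophenyl or 4-carboxyphenyl group, or a pyridine ring, would read at this place, in a series where every value shown lies in the same weak range.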